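A few compounds are considered here, and "the series" means these few. Any claim that something is new, unique, unknown or untested is made for them only; others in the source may bear on it.

Measured compounds:
compound 1, `Cc1c(-c2cc(Cl)cc(Cl)c2)c(C(=O)O)nn1-c1nc(-c2ccncc2)c(SC(C)C)s1`, "not active" (no number reported), without a number
compound 2, `Cc1nn(-c2nc(-c3ccc(Cl)c(Cl)c3)c(SC(C)C)s2)c(C(=O)O)c1-c1cccc(Cl)c1C`, 5100 nM

Among the measured compounds shown here, in a functional assay on BJAB cells (Homo sapiens) for antiproliferative activity, with a stated time of 4 days (on this read-out higher numbers stand for an effect only at larger amounts of compound and lower numbers for an effect already at smaller amounts), compound 2 gives 5100 nM, the only number in this small set; compound 1 is reported as "not active" (no number reported), so no number stands beside it and nothing can be said about the size of any gap between the two. Compound 3, `Cc1nn(-c2nc(-c3ccc(Cl)c(Cl)c3)c(SC(C)C)s2)c(C(=O)O)c1-c1ccc(C(F)(F)F)cc1`, has not yet been measured in this assay. It differs from compound 2 in one place: 4-(trifluoromethyl)phenyl in place of 3-chloro-2-methylphenyl on an aromatic carbon. For the measured compounds named here, no step between measured compounds is known here, so the size of this change can only be expected, not read from the data. The account expects a small step, no larger than the usual scatter, and if anything toward an effect only at larger amounts. Compound 3 is expected to give 6500 nM, with a range from 2000 nM to 20000 nM. The expected step of a 1.3-fold higher number from compound 2 to compound 3 (0.11 log units; within the scatter) is therefore estimated to stay close to where compound 2 stands.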

Compound 3, half-maximal effective concentration: 3500 nM
The estimate for compound 3 lay 1.9-fold (0.27 log units) above the measured number; measured number inside the range.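

In this assay, the first step readable at this position is a 1.5-fold lower number from compound 2 to compound 3 (0.16 log units; within the scatter), so exchanging 3-chloro-2-methylphenyl for 4-(trifluoromethyl)phenyl on this aromatic carbon leaves compound 2 and compound 3 level within the scatter. The position therefore accepts two differently substituted phenyl rings, both with no hydrogen-bond donors or acceptors and no net charge, without a step beyond the scatter. No measurement here bears on why the two compounds stand level.

On these data alone, it remains open whether a group of another kind at this position, such as a phenyl ring carrying an amine or a carboxylic acid, would leave the number where it stands. A pyridine ring in place of the phenyl ring poses the same open question.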